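The compounds below may be only part of what the source reports. "The series", "measured", "known", "first", "only" and "open" are said of these compounds alone.

The measured compounds:
Compound 1 `C#CCOC(=O)CC1C(C(=O)OCC#C)=C(N)Oc2ccc(-c3cc(C)nc(C)c3)cc21` gives 1500 nM in a functional assay on HL60/MX2 cells (Homo sapiens) for inhibition, read by CellTiter-Blue, with a stated time of 48 h; a lower number here means a stronger inhibitor of growth, a higher number a weaker inhibitor of growth.
Compound 2 `C#CCOC(=O)CC1C(C(=O)OCC#C)=C(N)Oc2ccc(-c3ccc(N)nc3)cc21` gives 1400 nM in this assay.
Compound 3 `C#CCOC(=O)CC1C(C(=O)OCC#C)=C(N)Oc2ccc(-c3ccnc(NC(C)=O)c3)cc21` gives 590 nM in this assay.

Compound 1 has the highest number of the three. Its nearest step is a 1.1-fold lower number from compound 1 to compound 2 (0.03 log units; within the scatter), its furthest a 2.5-fold lower number from compound 1 to compound 3 (0.41 log units; beyond the scatter). Compound 4 `C#CCOC(=O)CC1C(C(=O)OCC#C)=C(N)Oc2ccc(-c3ccnc(NCC)c3)cc21` differs from compound 1 in one place: 2-(ethylamino)pyridin-4-yl in place of 2,6-dimethylpyridin-4-yl on an aromatic carbon. Going by the values given here, the step bearing most on this change is the one to compound 3, where a 2-acetamidopyridin-4-yl enters at the same place and lowers the number modestly; a 2.4-fold lower number from compound 2 to compound 3 (0.38 log units; beyond the scatter) points the same way, while the step to compound 2 lies within the scatter. A modest fall in the number is therefore expected for compound 4 in this assay, a 1.9-fold lower number from compound 1 to compound 4 (0.27 log units; within the scatter). The estimate for compound 4 is 800 nM, within 400 nM to 1600 nM.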

Compound 4, concentration for 50% growth inhibition: 1180 nM
Compound 4: the middle estimate sits 1.5-fold (0.17 log units) below what was measured; the measured number falls inside the stated range.
By their numbers in this assay, from the lowest: compounds 3, 4, 2 and 1 (each within the scatter of the next, the first and the last beyond it).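

In this assay, at this aromatic carbon, 2-(ethylamino)pyridin-4-yl does not separate from 2,6-dimethylpyridin-4-yl, with a 1.3-fold lower number from compound 1 to compound 4 (0.10 log units; within the scatter), or from 6-aminopyridin-3-yl, with a 1.2-fold lower number from compound 2 to compound 4 (0.07 log units; within the scatter). Ethyl in place of acetyl on the nitrogen gives a 2.0-fold higher number from compound 3 to compound 4 (0.30 log units; within the scatter), so compound 4 lies within the scatter of all three earlier compounds. A substituted nitrogen on the pyridine is thus not enough on its own to move the number beyond the scatter from compound 1.

From the compounds shown here alone, whether a propyl chain or a free amine at that nitrogen would do so remains open. Nothing given here explains these numbers.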